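This account rests on a few compounds, and the source may have more. Where it says the series, first, only, none or still open, it means among the compounds named here.

Measured so far:
compound 1 `O=C(CSc1nnc(-c2ccncc2)o1)N/N=C/c1ccc(Br)cc1` — 18600 nM
compound 2 `O=C(CSc1nnc(-c2ccncc2)o1)N/N=C/c1ccccc1F` — 16000 nM

Both numbers come from a functional assay on HepG2 cells (Homo sapiens) for cytotoxicity, read by MTT assay, with a stated time of 48 h; on this read-out lower numbers stand for stronger inhibition and higher numbers for weaker inhibition. Within the data shown here, compound 2 holds the lower of the two, but the only step available, a 1.2-fold lower number from compound 1 to compound 2 (0.07 log units; within the scatter), does not separate the two compounds beyond the scatter.

Compound 3 `O=C(CSc1nnc(-c2ccncc2)o1)N/N=C/c1ccccc1[N+](=O)[O-]` has not yet been measured. It differs from compound 2 by nitro in place of fluoro on an aromatic carbon. Among the measured compounds shown here, the one measured step that bears on this change is the exchange of the aryl group on the carbon with a double bond to nitrogen, from compound 1 to compound 2, and that step stayed within the scatter. Exchanging one small substituent for another on the same ring therefore gives no ground to expect a step beyond the scatter in this assay, in either direction.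

For compound 3 the expected value is 15000 nM, with a range from 6000 nM to 40000 nM. The step this estimate means for compound 3, a 1.1-fold lower number from compound 2 to compound 3 (0.03 log units; within the scatter), is expected to stay within the scatter.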

Compound 3, half-maximal inhibitory concentration: 24700 nM
For compound 3 the middle estimate is 1.6-fold (0.22 log units) below the measured one; low and high end bracket the measured number.
By their numbers in this assay, from the lowest: compounds 2, 1 and 3 (each within the scatter of the next).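

In this assay, nitro in place of fluoro on an aromatic carbon, ortho to a large group, gives a 1.5-fold higher number from compound 2 to compound 3 (0.19 log units; within the scatter) and so shows that this place takes 3 heavy atoms instead of a single fluorine without a step beyond the scatter. The exchange of 4-bromophenyl for 2-nitrophenyl gives a 1.3-fold higher number from compound 1 to compound 3 (0.12 log units; within the scatter) and adds a second such step, so no aryl group shown here separates from another in this cytotoxicity read-out. No measurement on hand offers an explanation for these numbers.

On these data alone, it remains open whether an amine or a carboxylic acid on this ring would give a step beyond the scatter. Also open, as far as these compounds go, is whether any change to the shared core, such as a longer chain in its linker, would do so.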